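Swapping the Aryl Group on a Triazole Ester

The compounds below may be only part of what the source reports. "The series", "measured", "known", "first", "only" and "open" are said of these compounds alone.

Three analogues sharing one core were examined in an ADME assay on L132 cells (Homo sapiens) for cytotoxicity, read by MTT assay, with a stated time of 48 h; a higher number here means a weaker inhibitor, a lower number a stronger inhibitor. Compound 1 `C/C(=C\CC/C(C)=C/CC[C@@H]1[C@@]2(C)CCC(=O)C(C)(C)[C@H]2CC[C@@]1(C)O)CC/C=C(\C)C(=O)OCc1cn(-c2ccc(F)c(Cl)c2)nn1` reaches only the limit of the assay, > 150000 nM, and this is a limit rather than a number. Compound 2 `C/C(=C\CC/C(C)=C/CC[C@@H]1[C@@]2(C)CCC(=O)C(C)(C)[C@H]2CC[C@@]1(C)O)CC/C=C(\C)C(=O)OCc1cn(C[C@@H]2O[C@H](n3ccc(=O)[nH]c3=O)C[C@H]2O)nn1` gives 148000 nM in this assay. Compound 3 `C/C(=C\CC/C(C)=C/CC[C@@H]1[C@@]2(C)CCC(=O)C(C)(C)[C@H]2CC[C@@]1(C)O)CC/C=C(\C)C(=O)OCc1cn(C[C@@H]2O[C@H](n3ccc(=O)[nH]c3=O)[C@H]3OC(C)(C)O[C@H]32)nn1` also returns a limit, > 150000 nM. Compound 1 thus stands at the limit of > 150000 nM in this assay, at which 2 of the 3 values shown sit. Compound 4 `C/C(=C\CC/C(C)=C/CC[C@@H]1[C@@]2(C)CCC(=O)C(C)(C)[C@H]2CC[C@@]1(C)O)CC/C=C(\C)C(=O)OCc1cn(-c2ccc(Cl)cc2)nn1` has not yet been measured in this assay. It differs from compound 1 by 4-chlorophenyl in place of 3-chloro-4-fluorophenyl on an aromatic nitrogen. Within the data shown here, no step between two measured compounds that differ in one place is available to guide the expectation. It is expected that a number no higher from compound 1 to compound 4 (the limit leaves the size open) amounts to no change beyond the usual scatter. Compound 4 is estimated at 150000 nM, with a range from 100000 nM to 200000 nM.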

Compound 4, half-maximal inhibitory concentration: > 150000 nM
Compound 4: only a limit was reported; the forecaster's own chance of this, stated with the estimate: 70%; the middle value sits exactly at the limit.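

In this assay, among these compounds, compound 4 gives > 150000 nM, which is a limit, as is the result for compound 1, so no step between the two can be read. The compounds shown leave open whether 4-chlorophenyl in place of 3-chloro-4-fluorophenyl changes cytotoxicity at all.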